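Swapping oxan-4-yl for oxan-3-yl in compound 1

A few compounds are considered here, and "the series" means these few. Any claim that something is new, unique, unknown or untested is made for them only; others in the source may bear on it.

- compound 1 `O=C(Nc1ccc(OC(F)(F)F)cc1)NC1CCN(C(=O)C2CCOCC2)CC1`: 94.1%
- compound 2 `CC(C)C(=O)N1CCC(NC(=O)Nc2ccc(OC(F)(F)F)c(F)c2)CC1`: 98.7%

In an ADME assay on a cell-free system (plasma, Homo sapiens) for protein binding, tested at 1 uM, compound 1 gives 94.1%, the higher unbound fraction of the two, while compound 2 gives 98.7%, a gap beyond the scatter. Compound 3 `O=C(Nc1ccc(OC(F)(F)F)cc1)NC1CCN(C(=O)C2CCCOC2)CC1` carries oxan-3-yl in place of oxan-4-yl on a carbonyl carbon. Among the compounds with values here, no measured pair shows this change, so the expectation rests on the structural comparison alone. The expected step a 1.0-fold higher unbound fraction from compound 1 to compound 3 (0.01 log units; within the scatter) is estimated to stay within the scatter, with no direction foreseen. Compound 3 is expected at 94%, with an estimated range from 90% to 97%.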

Compound 3, plasma protein binding: 94.1%
Beside the measured number, compound 3's estimate is 1.0-fold (0.01 log units) (unbound fraction) above it; the range from low to high includes it.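

In this assay, within the data shown here, oxan-3-yl in place of oxan-4-yl on a carbonyl carbon brings no change at the digits printed from compound 1 to compound 3 (within the scatter) and so gives the first reading of a change at this position alone. Between these two attachments of the same ring, this read-out draws no distinction on the core of compound 1. No available evidence bears on why this is so. The compounds shown leave open whether a group of another kind on this carbonyl carbon, such as a piperidine bearing a basic amine or a chain ending in a carboxylic acid, would move plasma protein binding. They also leave open whether oxan-3-yl would read the same on the core of compound 2.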